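The compounds below may be only part of what the source reports. "The series", "measured", "known", "first", "only" and "open" are said of these compounds alone.

Compound 1 `CC(C)CCn1cnc2c(Nc3ccc(Cl)cc3)nc(N[C@H]3CC[C@H](N)CC3)nc21`: 2700 nM
Compound 2 `CCCCCCn1cnc2c(Nc3ccc(Cl)cc3)nc(N[C@H]3CC[C@H](N)CC3)nc21`: 4200 nM
Compound 3 `COc1cc(Nc2nc(N[C@H]3CC[C@H](N)CC3)nc3c2ncn3CCC(C)C)cc(OC)c1`: 4500 nM

All three values come from a functional assay on MCF7 cells (Homo sapiens) for inhibition, read by fluorescence, with a stated time of 72 h; on this read-out higher numbers stand for weaker inhibition of growth and lower numbers for stronger inhibition of growth. Compound 3, at 4500 nM, lies within the scatter of the other two, so the three cannot be ranked. Compound 4 `CCCCCCn1cnc2c(Nc3cc(OC)cc(OC)c3)nc(N[C@H]3CC[C@H](N)CC3)nc21` differs from compound 3 only in its chain: butyl in place of isopropyl on a saturated chain carbon, two bonds along the chain from an aromatic nitrogen. The same change appears once among the measured compounds, as a 1.6-fold higher number from compound 1 to compound 2 (0.19 log units; within the scatter). The other measured step, a 1.7-fold higher number from compound 1 to compound 3 (0.22 log units; within the scatter), changes a different group and says little about the chain. On this single small precedent, no step beyond the scatter is expected in this assay, though a slightly higher number is possible. The estimated step is a 1.3-fold higher number from compound 3 to compound 4 (0.12 log units; within the scatter). For compound 4 the expected value is 6000 nM, within an estimated range from 3000 nM to 12000 nM.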

Compound 4, concentration for 50% growth inhibition: 3500 nM
Beside the measured number, compound 4's estimate is 1.7-fold (0.23 log units) above it; the measured number falls inside the stated range.
By their numbers in this assay, from the lowest: compounds 1, 4, 2 and 3 (each within the scatter of the next).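

The change of isopropyl to butyl on the chain now has a second reading on a different core, a 1.3-fold lower number from compound 3 to compound 4 (0.11 log units; within the scatter), and it stays small on both: the same change on two cores in this assay, a 1.6-fold higher number (0.19 log units; within the scatter) from compound 1 to compound 2 and a 1.3-fold lower number (0.11 log units; within the scatter) from compound 3 to compound 4, 2.0-fold (0.30 log units) apart, within the scatter of two such steps

Likewise, 3,5-dimethoxyphenyl in place of 4-chlorophenyl now reads a 1.2-fold lower number from compound 2 to compound 4 (0.08 log units; within the scatter), again small on both cores: the same change on two cores in this assay, a 1.7-fold higher number (0.22 log units; within the scatter) from compound 1 to compound 3 and a 1.2-fold lower number (0.08 log units; within the scatter) from compound 2 to compound 4, 2.0-fold (0.30 log units) apart, within the scatter of two such steps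

Neither change, then, moves the number beyond the scatter, and neither shows any dependence on the other.

Still open, going by these compounds, is whether a chain ending in an amine or a carboxylic acid at this place, or a much longer chain, would give a step beyond the scatter.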